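A few compounds are considered here, and "the series" means these few. Any claim that something is new, unique, unknown or untested is made for them only; others in the source may bear on it.

Compound 1 `Cc1cc(-c2ccc(O)cc2)c2ncc(CSCCc3ccccc3)n2c1` and compound 2 `Cc1cc(-c2cccc(O)c2)c2ncc(CSCCc3ccccc3)n2c1` share one core. In an ADME assay on HEL cells (Homo sapiens) for cytotoxicity, with a stated time of 3 days (a higher number here means that more compound is tolerated, a lower number that less compound is tolerated), compound 1 gives 20 ug/mL and compound 2 gives 20 ug/mL, so that no change at the digits printed from compound 1 to compound 2 (within the scatter). Compound 3 `Cc1cc(-c2ccc(O)cc2)cn2c(CSCCc3ccccc3)cnc12` carries the same groups on a different core. In this assay compound 3 gives >= 100 ug/mL, which is a limit of the assay and not a number, the situation described by the limit of >= 100 ug/mL in this assay, at which 1 of the 3 values shown sits. Compound 4 `Cc1cc(-c2ccsc2)cn2c(CSCCc3ccccc3)cnc12` differs from compound 3 in one place: thiophen-3-yl in place of 4-hydroxyphenyl on an aromatic carbon. Going by the values given here, no measured step swaps the hydroxyphenyl for another ring; the only step measured, no change at the digits printed from compound 1 to compound 2 (within the scatter), shifts a hydroxyl without effect. Compound 4 is therefore expected to show little change, an estimated step of a number no higher from compound 3 to compound 4 (the limit leaves the size open). The estimate for compound 4 is 100 ug/mL, with a range from 25 ug/mL to 100 ug/mL.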

Compound 4, minimum cytotoxic concentration: >= 4 ug/mL
Compound 4: a limit, no number; the forecaster's own chance of this, stated with the estimate: 60%; the middle value lies beyond the limit too.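

In this assay compound 3 gives >= 100 ug/mL, a limit of the assay and not a number. Going by these compounds alone, compound 4 gives >= 4 ug/mL, also a limit, so no step from compound 3 can be read. As far as these compounds go, whether thiophen-3-yl in place of 4-hydroxyphenyl changes how much compound is tolerated stays open.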